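Chain unsaturation in a kallikrein-7 inhibitor series

This account rests on a few compounds, and the source may have more. Where it says the series, first, only, none or still open, it means among the compounds named here.

Measured compounds:
- compound 1, `CCCCCCCCCCCCC/C(O)=C1/C(=O)[C@H](Cc2ccccc2)N(C(=O)OC(C)(C)C)C1=O`: 1700 nM
- compound 2, `CCCCCCCCCCCCCCC/C(O)=C1/C(=O)[C@H](Cc2ccccc2)N(C(=O)OC(C)(C)C)C1=O`: 2900 nM
- compound 3, `CCCCCCCCCCCCCCCCC/C(O)=C1/C(=O)[C@H](Cc2ccccc2)N(C(=O)OC(C)(C)C)C1=O`: 2800 nM

These three compounds share one core and differ only in the length of a saturated chain. In an assay on isolated protein for inhibition of kallikrein-7 (Homo sapiens) (a lower number here means a stronger inhibitor, a higher number a weaker inhibitor), compound 3 gives 2800 nM. Its value sits close to that of compound 2, with a 1.0-fold lower number from compound 2 to compound 3 (0.02 log units; within the scatter), and its distance from compound 1 is a 1.6-fold higher number from compound 1 to compound 3 (0.22 log units; within the scatter). The remaining step, a 1.7-fold higher number from compound 1 to compound 2 (0.23 log units; within the scatter), is also within the scatter, so the three measured compounds cannot be separated from one another on these numbers.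

Compound 4, `CCCCCCCC/C=C\CCCCCCC/C(O)=C1/C(=O)[C@H](Cc2ccccc2)N(C(=O)OC(C)(C)C)C1=O`, has not yet been measured. It differs from compound 3 by dec-1-en-1-yl in place of decyl on a saturated chain carbon, seven bonds along the chain from a double-bonded chain carbon. For the measured compounds named here, no measured step involves a double bond in the chain, so none bears directly on this change; the only steps available, all of them chain-length changes, stayed within the scatter. On that basis the expectation is a step of a 1.1-fold lower number from compound 3 to compound 4 (0.05 log units; within the scatter), that is, none beyond the scatter. Compound 4 is therefore estimated at 2500 nM, with a range from 900 nM to 7000 nM.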

Compound 4, half-maximal inhibitory concentration: 2500 nM
For compound 4 middle estimate and measured number coincide at the digits printed; the measured number falls inside the stated range.
By their numbers in this assay, from the lowest: compounds 1, 4, 3 and 2 (each within the scatter of the next).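

For the compounds shown here, until now only the length of a saturated chain had varied; compound 4 is the first with a double bond in that chain. In this assay, dec-1-en-1-yl in place of decyl gives a 1.1-fold lower number from compound 3 to compound 4 (0.05 log units; within the scatter) and so adds a change of a different kind, not just of length, that stays within the scatter, as do the comparisons with the two other chains, a 1.2-fold lower number from compound 2 to compound 4 (0.06 log units; within the scatter) and a 1.5-fold higher number from compound 1 to compound 4 (0.17 log units; within the scatter) as well. Nothing available here explains this result, and all four compounds remain inseparable on these numbers.

Still open, as far as these compounds go, is whether a double bond elsewhere along the chain, or a second double bond, would also stay within the scatter. Every chain shown is pure carbon, so a chain carrying a carboxylic acid or an amine, or a much shorter chain, remains untested here.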